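The compounds below may be only part of what the source reports. "The series", "measured", "known", "first", "only" and "open" are said of these compounds alone.

Measured compounds in a functional assay on BT-549 cells (Homo sapiens) for inhibition, read by MTT assay, with a stated time of 48 h; on this read-out higher numbers stand for weaker inhibition and lower numbers for stronger inhibition:
Compound 1 `O=C1Nc2cc(Br)ccc2/C1=C\c1cccc(OCc2cn(Cc3ccccc3)nn2)c1` gives > 50000 nM, a limit of the assay rather than a number.
Compound 2 `CC(=O)c1ccc2c(c1)/C(=C/c1cccc(OCc3cn(Cc4ccccc4)nn3)c1)C(=O)N2` gives > 50000 nM, likewise a limit.
Compound 3 `CC(=O)c1ccc2c(c1)/C(=C\c1cccc(OCc3cn(Cc4ccccc4)nn3)c1)C(=O)N2` gives > 50000 nM, also a limit.

Compound 3 therefore stands only at the ceiling of this assay; no number is known for it. Going by the values given here, the one step between measured compounds, a step that the two limits leave unreadable from compound 2 to compound 3, concerns configuration alone (the fact that compounds 2 and 3 differ only in the configuration as drawn) and is left unreadable by the two limits (the limit of > 50000 nM in this assay, at which 3 of the 3 values shown sit), so it gives no handle on the size of any change.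

Compound 4 `COc1ccc(Cc2ccc3c(c2)/C(=C\c2cccc(OCc4cn(Cc5ccccc5)nn4)c2)C(=O)N3)cc1` differs from compound 3 by 4-methoxybenzyl in place of acetyl on an aromatic carbon. No measured step touches this position or this kind of exchange, so nothing in the series shown reads on it in either direction. Among the compounds with values here, with every value so far sitting at the same limit, the expectation for compound 4 in this assay rests on that alone: most likely it too returns a limit, and the step of an at least 1.2-fold lower number from compound 3 to compound 4 (0.09 log units; that floor lies within the scatter) is expected to be not readable beyond the scatter. Compound 4 is accordingly estimated at 40000 nM, within a range of 5000 nM to 200000 nM, with the working assumption that the assay again reports only a limit.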

Compound 4, half-maximal inhibitory concentration: > 50000 nM
Compound 4: no number, only a limit (the forecaster's own chance of this, stated with the estimate: 70%); at least 1.2-fold (0.09 log units) between middle value and limit.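

The step between compound 3 and compound 4 cannot be read, because both values are limits and not numbers: the limit of > 50000 nM in this assay, at which 4 of the 4 values shown sit.

The compounds shown leave open whether 4-methoxybenzyl and acetyl differ at all in their effect in this assay, and whether any change on the shared core would give a number there.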